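Moving the hydroxyl on a triaryl pyridine cytotoxicity series

The source may hold more compounds than are shown below. What is called first, only, known or untested is meant among the compounds shown, and "the series" means these compounds.

Of the compounds shown here, three of the shared core have been measured. Compound 1 `Oc1cccc(-c2cc(-c3ccc(Cl)cc3)nc(-c3cccnc3)c2)c1` gives 18100 nM in a functional assay on T47D cells (Homo sapiens) for cytotoxicity, read by CCK-8 assay and cell counting, with a stated time of 2 days; a higher number here means a weaker inhibitor, a lower number a stronger inhibitor. Compound 2 `Oc1cccc(-c2cc(-c3ccccc3)nc(-c3ccc(Cl)cc3)c2)c1` gives 11300 nM, and compound 3 `Oc1cccc(-c2cc(-c3ccccc3)nc(-c3cccc(Cl)c3)c2)c1` gives 3700 nM. Compound 2 stands second highest of the three numbers; its nearest neighbour is compound 1, and the step of a 1.6-fold lower number from compound 1 to compound 2 (0.20 log units; within the scatter) lies within the scatter, while the step of a 3.1-fold lower number from compound 2 to compound 3 (0.48 log units; beyond the scatter) is beyond it.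

Compound 4 `Oc1ccc(-c2cc(-c3ccccc3)nc(-c3ccc(Cl)cc3)c2)cc1` is not yet measured. It differs from compound 2 in one place: 4-hydroxyphenyl in place of 3-hydroxyphenyl on an aromatic carbon. Neither measured step touches the hydroxyphenyl group; one swaps phenyl for pyridin-3-yl and the other moves a chloro substituent, so no shown step bears directly on this change. With nothing to anchor a direction, compound 4 is expected to sit close to compound 2, with the step of a 1.0-fold lower number from compound 2 to compound 4 (0.01 log units; within the scatter) estimated to lie within the scatter. For compound 4 the estimate is 11000 nM, in a range from 4000 nM to 30000 nM.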

Compound 4, half-maximal inhibitory concentration: 4270 nM
Estimate against measurement, compound 4: 2.6-fold (0.41 log units) above, and the stated range covers the measured number.
By their numbers in this assay, from the lowest: compounds 3 and 4 (each within the scatter of the next); then compounds 2 and 1 (each within the scatter of the next).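

In this assay, the position of the hydroxyl on this ring is not neutral: putting 4-hydroxyphenyl in place of 3-hydroxyphenyl gives a 2.6-fold lower number from compound 2 to compound 4 (0.42 log units; beyond the scatter), a modest step. This is the first step shown that touches the hydroxyphenyl group, which stands opposite the ring nitrogen, and the two groups have the same atoms, joined differently, so the change lies in the point of attachment of the hydroxyl alone. Nothing shown gives a reason for this difference.

On these data alone, the step is read on a single background, so it remains open whether the same move would hold alongside the 3-chlorophenyl group of compound 3 or the pyridin-3-yl group of compound 1. As far as these compounds go, it also remains open how this position would respond if an amine, a methoxy group or a carboxylic acid took the place of the hydroxyl.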